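This account rests on a few compounds, and the source may have more. Where it says the series, first, only, none or still open, it means among the compounds named here.

Three compounds share one core and one read-out. Compound 1 `O=C(O)CCc1ccc(NCc2ccc(Cl)cc2)cc1` gives 1000 nM in a functional assay for agonist activity at Free fatty acid receptor 1 (Homo sapiens); on this read-out lower numbers stand for an effect already at smaller amounts and higher numbers for an effect only at larger amounts of compound. Compound 2 `O=C(O)CCc1ccc(NCc2ccc(-c3ccccc3)cc2)cc1` gives 251 nM in this assay, and compound 3 `O=C(O)C1CC1c1ccc(NCc2ccc(-c3ccccc3)cc2)cc1` gives 39.8 nM in this assay. Compound 2 thus stands second highest of the three numbers: there is a 4.0-fold lower number from compound 1 to compound 2 (0.60 log units; beyond the scatter) and a 6.3-fold lower number from compound 2 to compound 3 (0.80 log units; beyond the scatter), both beyond the scatter.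

Compound 4 `O=C(O)CCc1ccc(NCc2ccc(C(F)(F)F)cc2)cc1` is not yet measured. It differs from compound 2 by trifluoromethyl in place of phenyl on an aromatic carbon. Among the compounds with values here, of the measured steps, only the one from compound 1 to compound 2 touches the same place on that ring, and it shows a 4.0-fold lower number from compound 1 to compound 2 (0.60 log units; beyond the scatter) when phenyl replaced chloro. The step from compound 2 to compound 3 alters another part of the molecule and does not bear on this change. Since the entering trifluoromethyl, with 4 heavy atoms and no ring, is closer in count to the chloro of compound 1 than to the phenyl it replaces, compound 4 is expected to move back toward compound 1, with a modest rise, a 3.2-fold higher number from compound 2 to compound 4 (0.50 log units; beyond the scatter). Compound 4 is therefore estimated at 800 nM, within a range from 300 nM to 2500 nM.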

Compound 4, half-maximal effective concentration: 2000 nM
For compound 4 the middle estimate is 2.5-fold (0.40 log units) below the measured one; the range from low to high includes it.
By their numbers in this assay, from the lowest: compound 3; then compound 2; then compounds 1 and 4 (each within the scatter of the next).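

In this assay, the new step shows that phenyl stands apart at this place on the ring: trifluoromethyl in its place gives an 8.0-fold higher number from compound 2 to compound 4 (0.90 log units; beyond the scatter). Trifluoromethyl and chloro, by contrast, cannot be told apart, with a 2.0-fold higher number from compound 1 to compound 4 (0.30 log units; within the scatter), so the two non-ring groups shown here sit at the same level and only phenyl lies clearly lower in number. No measurement is available that would explain this difference between phenyl and the two smaller groups.

From the compounds shown here alone, it remains open whether a cyclohexyl, a pyridyl or a benzyloxy group at this place would match phenyl or fall back to the level of chloro and trifluoromethyl. Going by these compounds, it is also open whether the step from phenyl to trifluoromethyl would be of the same size with the 2-carboxycyclopropyl group of compound 3.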